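Methoxy in place of hydrogen on the fused ring

The source may hold more compounds than are shown below. What is called first, only, known or untested is meant among the compounds shown, and "the series" means these compounds.

Compound 1 `CCc1cc(Nc2nc(N[C@@H](C)c3ccc(F)cc3)nc3cc(F)ccc23)n[nH]1` and compound 2 `CCc1cc(Nc2nc(N[C@@H](C)c3ccc(F)cc3)nc3ccccc23)n[nH]1` differ only by hydrogen in place of fluoro on an aromatic carbon. In an assay on isolated protein for inhibition of G protein-coupled receptor kinase 6 (Homo sapiens), read by scintillation counting, radiometric assay and 33P incorporation, with a stated time of 80 min, in the presence of a further agent that is not named here (on this read-out higher numbers stand for weaker inhibition and lower numbers for stronger inhibition), compound 1 gives 100 nM, and compound 2 gives 120 nM. The step of a 1.2-fold higher number from compound 1 to compound 2 (0.08 log units; within the scatter) is flat. Compound 2 thus holds the higher of the two numbers, yet within the scatter of compound 1. Compound 3 `CCc1cc(Nc2nc(N[C@@H](C)c3ccc(F)cc3)nc3ccc(OC)cc23)n[nH]1` carries methoxy in place of hydrogen on an aromatic carbon. For the measured compounds named here, only that flat fluoro-to-hydrogen step bears on this change, so in this assay no step beyond the scatter is expected: a 1.1-fold higher number from compound 2 to compound 3 (0.03 log units; within the scatter). Compound 3 is accordingly estimated at 130 nM, with a range of 60 nM to 300 nM.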

Compound 3, half-maximal inhibitory concentration: 140 nM
Beside the measured number, compound 3's estimate is 1.1-fold (0.03 log units) below it; the range from low to high includes it.
By their numbers in this assay, from the lowest: compounds 1, 2 and 3 (each within the scatter of the next).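

In this assay, a second position on the fused system now has a reading: methoxy on this aromatic carbon, with its 2 heavy atoms, leaves the number flat (a 1.2-fold higher number from compound 2 to compound 3 (0.07 log units; within the scatter)). For the compounds shown here, the earlier pair covered only hydrogen in place of fluoro at a different carbon, so this is the first substituent larger than a single atom on the fused ring, and it too stays within the scatter. No supporting evidence bears on this flat result.

Still open, going by these compounds, is whether this carbon stays flat with an amine, a carboxylic acid or a longer chain such as butoxy. Also open, on these data alone, is whether methoxy behaves the same way on the other carbons of that ring.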